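A few compounds are considered here, and "the series" means these few. Any claim that something is new, unique, unknown or untested is made for them only; others in the source may bear on it.

In a functional assay on A549 cells (Homo sapiens) for cytotoxicity, read by MTT assay, with a stated time of 72 h (a lower number here means a stronger inhibitor, a higher number a weaker inhibitor), compound 1 `COc1cc(Nc2nc3ccccc3nc2S(=O)(=O)c2ccccc2)cc(OC)c1` gives 70 nM, and compound 2 `Nc1cccc(Nc2nc3ccccc3nc2S(=O)(=O)c2ccccc2)c1` gives 1590 nM. Compound 3 `O=S(=O)(c1ccccc1)c1nc2ccccc2nc1Nc1ccc(F)cc1` reaches only a limit, > 50000 nM. Compound 2 therefore holds the higher of the two actual numbers, while the remaining result is not a number.

Compound 4 `COc1ccc(S(=O)(=O)c2nc3ccccc3nc2Nc2cccc(N)c2)cc1` departs from compound 2 by a single change, methoxy in place of hydrogen on an aromatic carbon, turning phenyl into 4-methoxyphenyl, para to a large group.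

Three measured steps are available, and each alters the group carried on the nitrogen: a 23-fold higher number from compound 1 to compound 2 (1.36 log units; beyond the scatter), an at least 710-fold higher number from compound 1 to compound 3 (2.85 log units; beyond the scatter) and an at least 31-fold higher number from compound 2 to compound 3 (1.49 log units; beyond the scatter). All three are large, although the last two rest on the limit of compound 3. None of them touches the ring that takes the methoxy. They show that the numbers can move sharply at another place in these compounds, but they offer no direct measure of this change and no direction for it.

In this assay, no step beyond the scatter is therefore the central expectation, with wide uncertainty on either side. The expected step is a 1.1-fold lower number from compound 2 to compound 4 (0.03 log units; within the scatter). For compound 4 the estimated value is 1500 nM. The expected range for compound 4 runs from 300 nM to 7000 nM.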

Compound 4, half-maximal inhibitory concentration: 340 nM
Compound 4: the middle estimate sits 4.4-fold (0.64 log units) above what was measured; measured number inside the range.
By their numbers in this assay, from the lowest: compound 1; then compound 4; then compound 2. At a limit, above all of these: compound 3.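

Going by these compounds alone, every earlier step in this assay altered the group on the nitrogen, so the step of a 4.7-fold lower number from compound 2 to compound 4 (0.67 log units; beyond the scatter) is the first reading at the phenyl that becomes 4-methoxyphenyl. It shows that this ring is not a silent place: methoxy in place of hydrogen on an aromatic carbon, para to a large group, moves the number beyond the scatter towards a stronger inhibitor, although the step is modest beside the large ones printed for changes on the nitrogen. The one line of supporting data concerns only the assay limit and does not bear on this change, so no cause can be given for the gain.

Within the data shown here, this single pair does not tell whether the same change would give a similar step with the 3,5-dimethoxyphenyl group of compound 1 on the nitrogen, since the shift is seen only with the 3-aminophenyl group of compound 2. It also leaves open whether an ethoxy group, a chlorine atom, a hydroxyl or an amine at this place would move the number in the same direction, or by as much, as methoxy does.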